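Tetrazole-bearing indole series: weak binders, one analogue projected

The source may hold more compounds than are shown below. What is called first, only, known or untested is meant among the compounds shown, and "the series" means these compounds.

Measured compounds:
- compound 1 `CCOC(=O)c1[nH]c2cc(Cl)ccc2c1C(NCC1CCCCC1)c1nnnn1Cc1ccc(OCc2ccccc2Br)cc1`: "not active" (no number reported)
- compound 2 `CCOC(=O)c1[nH]c2cc(Cl)ccc2c1C(NCC1CCCCC1)c1nnnn1Cc1ccc(Cl)cc1`: "not active" (no number reported)
- compound 3 `CCOC(=O)c1[nH]c2cc(Cl)ccc2c1C(NCC1CCCCC1)c1nnnn1-c1ccc(Cl)cc1`: 117000 nM

All three compounds share one core and differ only in the group carried on the tetrazole. In an assay for binding affinity to E3 ubiquitin-protein ligase Mdm2 (Homo sapiens), read by fluorescence polarization, with a stated time of 15 min (a higher number here means a weaker inhibitor, a lower number a stronger inhibitor), compound 1 is reported as "not active" (no number reported). In this assay compound 2 is likewise reported as "not active" (no number reported), so no single number describes where compound 2 stands; the only figure in the set belongs to compound 3, which in this assay gives 117000 nM. On the numbers shown, compound 2 therefore stands among the entries without a value, in a set whose one measured member is very weak.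

Compound 4 `CCOC(=O)c1[nH]c2cc(Cl)ccc2c1C(NCC1CCCCC1)c1nnnn1Cc1ccc(OCc2ccccc2Cl)cc1` is not yet measured. Compared with compound 2 the change is (2-chlorobenzyl)oxy in place of chloro on an aromatic carbon. Among the measured compounds shown here, no measured step of this kind exists in the set; compound 1, which carries the closely related (2-bromobenzyl)oxy group, gives only "not active" (no number reported). The expectation in this assay is therefore no step beyond the scatter, with a considerable chance that the assay again reports only an inactive entry. For compound 4 the estimated value is 150000 nM, within a range of 40000 nM to 600000 nM.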

Compound 4, inhibition constant: "not active" (no number reported)
Nothing numeric was reported for compound 4; no gap can be computed for the estimate.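

In this assay compound 2 gives "not active" (no number reported) and compound 4 gives "not active" (no number reported); no step can be read between them. No supporting data bear on this result. The compounds shown leave open whether any group on the tetrazole gives binding clearly stronger than that of compound 3 at 117000 nM.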